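Swapping the Dichlorophenyl Group for a Cyanophenyl Group

The compounds below may be only part of what the source reports. "The series", "measured", "known", "first", "only" and "open" are said of these compounds alone.

Compound 1 `N#Cc1cc2c(nc1N1CCC(F)(C(=O)NS(=O)(=O)Cc3ccc(Cl)cc3)CC1)COC2=O`: 37200 nM
Compound 2 `N#Cc1cc2c(nc1N1CCC(C(=O)NS(=O)(=O)Cc3ccccc3)CC1)CCCC2=O`: 117000 nM
Compound 3 `N#Cc1cc2c(nc1N1CCC(C(=O)NS(=O)(=O)Cc3cc(Cl)cc(Cl)c3)CC1)COC2=O`: 30500 nM

In a functional assay (Platelet, plasma) for inhibition, with Homo sapiens as the target (a higher number here means a weaker inhibitor, a lower number a stronger inhibitor), compound 3 gives 30500 nM, within the scatter of compound 1 at 37200 nM, while compound 2, at 117000 nM, stands higher, beyond the scatter. Compound 4 `N#Cc1ccc(CS(=O)(=O)NC(=O)C2CCN(c3nc4c(cc3C#N)C(=O)OC4)CC2)cc1` departs from compound 3 in one place: 4-cyanophenyl in place of 3,5-dichlorophenyl on a saturated chain carbon bound to a sulfonyl sulfur. It carries 4-cyanophenyl in place of 3,5-dichlorophenyl on a saturated chain carbon bound to a sulfonyl sulfur. Within the data shown here, no measured pair isolates this change. Among the measured compounds shown here, the only measured compound without chlorine is compound 2 at 117000 nM, and its core also differs, so the expectation is tentative. A modest move toward weaker inhibition is expected, estimated as a 2.0-fold higher number from compound 3 to compound 4 (0.29 log units; within the scatter). For compound 4 the estimated value is 60000 nM, with an expected range of 22000 nM to 150000 nM.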

Compound 4, half-maximal inhibitory concentration: 8900 nM
Compound 4: the middle estimate sits 6.7-fold (0.83 log units) above what was measured; measured number outside the range, below it.
By their numbers in this assay, from the lowest: compound 4; then compounds 3 and 1 (each within the scatter of the next); then compound 2.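

In this assay, 4-cyanophenyl in place of 3,5-dichlorophenyl on a saturated chain carbon bound to a sulfonyl sulfur gives a 3.4-fold lower number from compound 3 to compound 4 (0.53 log units; beyond the scatter) and is the only single-place step among these compounds. It shows that inhibition responds to the group at this position and that a ring without chlorine can be the stronger inhibitor here. No measured evidence accounts for the step. The compounds shown do not separate the entry of the nitrile from the loss of both chlorines. On these data alone, whether a carboxylic acid or a primary amide could replace the nitrile also remains open.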